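The compounds below may be only part of what the source reports. "The series", "measured", "known", "first", "only" and "open" are said of these compounds alone.

Compound 1 `COc1cc(-c2cc(/C=C/C(=O)c3ccc(Cl)c(Cl)c3)[nH]n2)cc(OC)c1OC`: -32%
Compound 2 `COc1ccc(-c2cc(/C=C/C(=O)c3cc(OC)c(OC)c(OC)c3)[nH]n2)cc1OC`: -61%
Compound 3 `COc1ccc(C(=O)/C=C/c2cc(-c3cc(OC)c(OC)c(OC)c3)n[nH]2)cc1`: -10%

All three were tested in a functional assay on HCT-116 cells (Homo sapiens) for cytotoxicity, read by sulforhodamine B assay, with a stated time of 48 h, tested at 100 uM; a lower number here means a stronger effect, a higher number a weaker effect of the compound at the concentration tested. Among them compound 3 stands highest, that is weakest: compound 1 lies lower by a margin beyond the scatter, and compound 2 lies lowest of all, also beyond the scatter. Compound 4 `COc1cc(-c2cc(/C=C/C(=O)c3ccc(F)c(F)c3)[nH]n2)cc(OC)c1OC` has not yet been measured. It differs from compound 3 in one place: 3,4-difluorophenyl in place of 4-methoxyphenyl on a carbonyl carbon. Going by the values given here, one measured step bears on this change: a number 22 percentage points higher from compound 1 to compound 3 (beyond the scatter), which replaced 3,4-dichlorophenyl by 4-methoxyphenyl on the same carbonyl carbon, the opposite direction to the present step, and with chlorine rather than fluorine. Reversing it suggests that placing 3,4-difluorophenyl on the carbonyl carbon should lower the number in this assay again, a modest strengthening of the effect, though the change from chlorine to fluorine leaves the size uncertain. Compound 4 is therefore expected to give about -25% in this assay, within a range from -45% to -5%. The step expected here is a number 15 percentage points lower from compound 3 to compound 4 (beyond the scatter).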

Compound 4, a percentage reported as activity, at one concentration (the size of the read-out at that concentration, not a potency): -52%
For compound 4 the middle estimate is 27 percentage points above the measured one; measured number below the stated range.
By their numbers in this assay, from the lowest: compounds 2 and 4 (each within the scatter of the next); then compound 1; then compound 3.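

Going by these compounds alone, on the carbonyl carbon, the choice of aryl group can matter more in this assay than the single earlier step suggested: 3,4-difluorophenyl in place of 4-methoxyphenyl gives a number 42 percentage points lower from compound 3 to compound 4 (beyond the scatter) in this one comparison. The two halogenated groups are not interchangeable either, as 3,4-difluorophenyl in place of 3,4-dichlorophenyl gives a number 20 percentage points lower from compound 1 to compound 4 (beyond the scatter) on the same carbonyl carbon. The halogen itself therefore changes the read-out, so the earlier contrast between 3,4-dichlorophenyl and 4-methoxyphenyl did not capture the full range at this place.

The compounds shown leave open how a phenyl ring with a single fluorine, or a group of another kind such as a carboxylic acid or an amine, would behave on this carbonyl carbon. No measurement here accounts for the differences among these groups.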